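The source may hold more compounds than are shown below. What is called first, only, known or untested is meant among the compounds shown, and "the series" means these compounds.

Of the compounds shown here, three share one core and have been measured in a functional assay (lung) for inhibition, with Cavia porcellus as the target; on this read-out lower numbers stand for stronger inhibition and higher numbers for weaker inhibition. Compound 1, with the structure `CCCC(CCc1nnn[nH]1)Cc1ccc(OCc2ccc3ccccc3n2)cc1`, gives 32 nM in this assay. Compound 3, with the structure `CCCC(CCc1nnn[nH]1)Cc1cccc(OCc2ccc3ccccc3n2)c1`, is built from the same atoms joined differently; how its core differs from that of compound 1 is not broken down here. In this assay compound 3 gives 16 nM. Compound 2, with the structure `c1ccc(C(CCc2nnn[nH]2)Cc2cccc(OCc3ccc4ccccc4n3)c2)cc1`, differs from compound 3 in one place: phenyl in place of propyl on a saturated chain carbon bound to two saturated chain carbons. In this assay compound 2 gives 24 nM. That change brought a 1.5-fold higher number from compound 3 to compound 2 (0.18 log units; within the scatter). Compound 1 and compound 2 give numbers that lie within the usual scatter of each other, and so do compound 1 and compound 3.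

Compound 4, with the structure `c1ccc(C(CCc2nnn[nH]2)Cc2ccc(OCc3ccc4ccccc4n3)cc2)cc1`, is not yet measured. It differs from compound 1 in one place: phenyl in place of propyl on a saturated chain carbon bound to two saturated chain carbons. This is the same change that turned compound 3 into compound 2, and the surroundings of the place are described in the same words in both pairs. Because compound 3 to compound 2 gave a 1.5-fold higher number from compound 3 to compound 2 (0.18 log units; within the scatter), a step of similar size is expected from compound 1 to compound 4, that is a 1.4-fold higher number from compound 1 to compound 4 (0.15 log units; within the scatter) in this assay. On that basis compound 4 is estimated to give about 45 nM in this assay, with a plausible range from 20 nM to 100 nM. Whether the measured number matches this expectation remains to be seen.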

Compound 4, half-maximal inhibitory concentration: 14 nM
Beside the measured number, compound 4's estimate is 3.2-fold (0.51 log units) above it; measured number below the stated range.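

In this assay, putting phenyl in place of propyl on a saturated chain carbon bound to two saturated chain carbons gave a 2.3-fold lower number from compound 1 to compound 4 (0.36 log units; beyond the scatter), a modest step that, unlike the earlier one, lies beyond the usual scatter of repeated measurements. Set beside that earlier step, the same change did not bring a step of the same size on the two cores, so the step seen on one core was not a reliable guide to the step on the other: the same change on two cores in this assay, a 1.5-fold higher number (0.18 log units; within the scatter) from compound 3 to compound 2 and a 2.3-fold lower number (0.36 log units; beyond the scatter) from compound 1 to compound 4, 3.4-fold (0.54 log units) apart, beyond the scatter of two such steps This shows that, in this series, the effect of the change depends on the core that carries it, but with only two pairs of compounds it gives no general rule for other cores and does not explain why the two steps differ.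

The compounds shown leave open how other groups on that saturated chain carbon would behave on each core, for example a longer chain such as hexyl, or an amine. They also leave open whether such groups would give steps that differ between the two cores in the way seen for phenyl and propyl.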